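The source may hold more compounds than are shown below. What is called first, only, known or untested is meant among the compounds shown, and "the series" means these compounds.

Measured in a functional assay on PANC-1 cells (Homo sapiens) for inhibition, read by MTT assay, with a stated time of 24 h, tested at 10 uM (a lower number here means less inhibition, a higher number more inhibition at the concentration tested (going by the name of the read-out)), the three compounds and their numbers are:

Compound 1 `CC(C)=CCOc1cc(=O)n(CCCO)c2c1CC(CC=C(C)C)C(C)(C)C2`: 7.5%
Compound 2 `COc1ccc(NC(=O)Oc2cc(=O)n(CCCO)c3c2CC(CC=C(C)C)C(C)(C)C3)cc1`: 0%
Compound 3 `COc1cccc(NC(=O)Oc2cc(=O)n(CCCO)c3c2CC(CC=C(C)C)C(C)(C)C3)c1`: 0%

Compound 3 stands level with compound 2: the step of no change at the digits printed from compound 2 to compound 3 (within the scatter) shows no difference at all, and the step of a number 7.5 percentage points lower from compound 1 to compound 3 (within the scatter) stays within the scatter of repeated measurements. In other words, none of the three compounds can be told apart on these numbers; all of them sit near the bottom of the percentage scale, showing little inhibition of the cells at the concentration tested.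

Compound 4 `CC(C)=CCC1Cc2c(OC(=O)Nc3ccc(F)c(Cl)c3)cc(=O)n(CCCO)c2CC1(C)C` is the next compound in line. It keeps the carbamate and the shared core of compound 3 and changes only the aromatic ring hanging from the amide-type nitrogen: 3-chloro-4-fluorophenyl in place of 3-methoxyphenyl on an amide-type nitrogen.

Going by the values given here, the step that bears most directly on this change is the one from compound 2 to compound 3, where a different arrangement of the same methoxyphenyl ring left the number untouched. The two steps from compound 1, which swapped a whole prenyl group for a carbamate, also stayed within the scatter. Among the compounds with values here, nothing measured so far points to movement in this assay from swapping one substituted phenyl for another, so the expected step of a number 2 percentage points higher from compound 3 to compound 4 (within the scatter) is none beyond the scatter. Compound 4 is therefore estimated at 2%, with a range from 0% to 12%.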

Compound 4, a percentage reported as inhibition, at one concentration (the size of the read-out at that concentration, not a potency): 0%
Estimate against measurement, compound 4: 2 percentage points above; the range from low to high includes it.
By their numbers in this assay, from the lowest: compounds 2, 3, 4 and 1 (each within the scatter of the next).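

Putting 3-chloro-4-fluorophenyl in place of 3-methoxyphenyl on the amide-type nitrogen gives no change at the digits printed from compound 3 to compound 4 (within the scatter) in this assay, and the comparison with the other methoxy compound reads the same, with no change at the digits printed from compound 2 to compound 4 (within the scatter). The earlier carbamates differed only in where the methoxy group sat on the ring, whereas this ring carries fluorine and chlorine and no oxygen, so a change in the kind of substituent, not just its place, also leaves the number unmoved; against the prenyl ether, the picture also holds, with a number 7.5 percentage points lower from compound 1 to compound 4 (within the scatter). No measurement here offers any explanation for this flat result.

All three carbamates share the same printed value at the bottom of the scale, so these compounds can only leave open whether some other group at this position would raise the number at all. An amine or a carboxylic acid on the phenyl ring, or a cyclohexyl ring in place of the phenyl, remains an open case, as does a longer chain in place of the hydroxypropyl chain on the shared core.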